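The compounds below may be only part of what the source reports. "The series", "measured", "known", "first", "only" and "open" are said of these compounds alone.

Three compounds share one core, a benzene ring carrying an amide arm on one side and a sulfonamide arm on the other. Compound 1 `O=C(NCc1ccc(CNS(=O)(=O)c2cccc(F)c2)cc1)c1cccnc1` gives 1000 nM in an assay on MDA-MB-231 cells for displacement of a labelled ligand from C-X-C chemokine receptor type 4 (Homo sapiens), read by fluorescence and microscopy, with stated times of 10 min and 30 min; a higher number here means that more compound is needed for the effect, a lower number that less compound is needed. Compound 2 `O=C(NCc1ccc(CNS(=O)(=O)c2ccccc2F)cc1)c1cccnc1` gives 100 nM in this assay, and the step of a 10-fold lower number from compound 1 to compound 2 (1.00 log units; beyond the scatter) shows how much a shift of the fluorine on the sulfonyl ring matters. Compound 3 `Cc1ccccc1C(=O)NCc1ccc(CNS(=O)(=O)c2ccc(F)cc2)cc1` gives 10 nM in this assay, the lowest of the three numbers, set apart from both others by steps beyond the scatter.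

Compound 4 `O=C(NCc1ccc(CNS(=O)(=O)c2ccc(F)cc2)cc1)c1cccnc1` is compound 3 with one change: pyridin-3-yl in place of 2-methylphenyl on a carbonyl carbon. Among the measured compounds shown here, no measured step touches this position, so no direct guide exists. Compounds 1 and 2 carry the pyridin-3-yl amide, but each also carries a differently placed fluorine on the sulfonyl ring, so their values cannot be read as the effect of the amide group alone. Their values do show that pyridin-3-yl amides can sit anywhere from 100 nM for compound 2 to 1000 nM for compound 1.

With that uncertainty, compound 4 is expected to give a higher number than compound 3, estimated at 50 nM, within a range from 10 nM to 300 nM, a step of a 5.0-fold higher number from compound 3 to compound 4 (0.70 log units; beyond the scatter).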

Compound 4, effective concentration (reported as EC, without a stated level of effect): 100 nM
Estimate against measurement, compound 4: 2.0-fold (0.30 log units) below; measured number inside the range.
By their numbers in this assay, from the lowest: compound 3; then compounds 2 and 4 (each within the scatter of the next); then compound 1.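

With the sulfonyl ring held as 4-fluorophenyl, the amide group can now be read on its own: pyridin-3-yl in place of 2-methylphenyl on a carbonyl carbon gives a 10-fold higher number from compound 3 to compound 4 (1.00 log units; beyond the scatter) in this assay, so this position clearly affects how much compound is needed. Compound 4 also completes a set of three pyridin-3-yl amides that differ only in where the fluorine sits, with a 10-fold lower number from compound 1 to compound 4 (1.00 log units; beyond the scatter) but no change at the digits printed from compound 2 to compound 4 (within the scatter), which leaves the 3-fluorophenyl compound as the one that stands apart within this set. No measurement shown here accounts for the size of either effect.

This single swap changes two things at once, removing a methyl group and placing a nitrogen in the ring, so the result cannot say which of them matters; a plain phenyl group at the same carbonyl carbon would help separate the two. From the compounds shown here alone, it also remains open whether 2-methylphenyl would give a similar gain with the fluorine placed differently, since that group appears here only with 4-fluorophenyl.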